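Chain end and chain length: compound 2 to compound 3

The source may hold more compounds than are shown below. What is called first, only, known or untested is meant among the compounds shown, and "the series" means these compounds.

In a functional assay on HCT-116 cells (Homo sapiens) for inhibition, read by MTT assay, with a stated time of 72 h (a lower number here means a stronger inhibitor, a higher number a weaker inhibitor), compound 2 (`CNC(=O)CCCCCCCn1nc(-c2ccc3oc(N)nc3c2)c2c(N)ncnc21`) gives 3150 nM and holds the lower of the two measured numbers, while compound 1 (`Nc1nc2cc(-c3nn(CCCCC(=O)NO)c4ncnc(N)c34)ccc2o1`) gives 34000 nM as the higher one. The next analogue is compound 3 (`Nc1nc2cc(-c3nn(CCCCCCC(=O)NO)c4ncnc(N)c34)ccc2o1`), and its difference from compound 2 is hydroxycarbamoyl in place of (methylcarbamoyl)methyl on a saturated chain carbon, six bonds along the chain from an aromatic nitrogen in short: hydroxycarbamoyl in place of (methylcarbamoyl)methyl on a saturated chain carbon, six bonds along the chain from an aromatic nitrogen. For the measured compounds named here, the only measured step that bears on this is large: an 11-fold lower number from compound 1 to compound 2 (1.03 log units; beyond the scatter) and it changes end group and chain length together. The data do not separate the two. Compound 3 carries the hydroxycarbamoyl of compound 1 six bonds along the chain instead of four. The expected step is a 3.9-fold lower number from compound 2 to compound 3 (0.60 log units; beyond the scatter) in this assay and this direction is a tentative estimate. Compound 3 is expected at 800 nM within 100 nM to 6000 nM on this estimate.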

Compound 3, half-maximal inhibitory concentration: 5390 nM
Beside the measured number, compound 3's estimate is 6.7-fold (0.83 log units) below it; low and high end bracket the measured number.
By their numbers in this assay, from the lowest: compounds 2 and 3 (each within the scatter of the next); then compound 1.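

With the hydroxycarbamoyl end kept, 2-(hydroxycarbamoyl)ethyl in place of hydroxycarbamoyl gives a 6.3-fold lower number from compound 1 to compound 3 (0.80 log units; beyond the scatter) in this assay and so shows that chain length alone moves the number, which the earlier pair, changing end group and chain together, could not separate. Hydroxycarbamoyl in place of (methylcarbamoyl)methyl, six bonds along the chain from an aromatic nitrogen, gives a 1.7-fold higher number from compound 2 to compound 3 (0.23 log units; within the scatter) and so, in this assay and on these two compounds, this change of chain end shows no effect beyond the scatter. No measurement at hand accounts for either step.

As far as these compounds go, whether a longer chain ending in hydroxycarbamoyl moves the number further, and whether a carboxylic acid as chain end behaves like hydroxycarbamoyl, remains open. Also open, from the compounds shown here alone, is whether the methylcarbamoyl end responds to chain length as the hydroxycarbamoyl end does.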